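This account rests on a few compounds, and the source may have more. Where it says the series, first, only, none or still open, it means among the compounds named here.

Values in a functional assay on HEK293 cells for antagonist activity at transient receptor potential cation channel subfamily V member 1 (Homo sapiens), read by calcium flux (a higher number here means a weaker inhibitor, a lower number a stronger inhibitor), for the three measured members of the series:

compound 1, `CN(c1nc2c(Nc3ccc(C(F)(F)F)cc3)ncnc2s1)c1c(Cl)cccc1Cl`: 502 nM
compound 2, `FC(F)(F)c1ccc(Nc2ncnc3sc(Nc4ccccc4C(F)(F)F)nc23)cc1`: 74 nM
compound 3, `Clc1cccc(Cl)c1Nc1nc2c(Nc3ccccc3)ncnc2s1`: 176 nM

Compound 3 stands second highest of the three numbers. Its nearest neighbour is compound 2, whose value of 74 nM is the lower one, by a gap beyond the scatter; furthest is compound 1, whose value of 502 nM is the higher one, again beyond the scatter.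

Compound 4, `O=S(=O)(c1ccc(Nc2ncnc3sc(Nc4c(Cl)cccc4Cl)nc23)cc1)N1CCCC1`, is not yet measured. It differs from compound 3 by a single change: (pyrrolidin-1-yl)sulfonyl in place of hydrogen on an aromatic carbon. Among the measured compounds shown here, no pair of measured compounds isolates this change. Compounds 1 and 2 carry a trifluoromethyl on the corresponding ring, but each also differs from compound 3 in a second place, so their values say nothing clean about a substituent at that position. The expectation for this assay is therefore a small step, if any, toward a lower number, likely within the scatter; the step from compound 3 to compound 4 is estimated at a 1.5-fold lower number from compound 3 to compound 4 (0.17 log units; within the scatter). For compound 4 the value is estimated at 120 nM, with a range from 40 nM to 400 nM.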

Compound 4, half-maximal inhibitory concentration: 1 nM
Compound 4: the middle estimate sits 120-fold (2.08 log units) above what was measured; measured number below the stated range.
By their numbers in this assay, from the lowest: compound 4; then compound 2; then compound 3; then compound 1.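

In this assay, the aromatic carbon para to a large group proves highly sensitive to substitution: (pyrrolidin-1-yl)sulfonyl in place of hydrogen gives a 180-fold lower number from compound 3 to compound 4 (2.25 log units; beyond the scatter), a large step beyond the scatter. Among the compounds shown here, this is the first clean reading of any change at this position, and it shows that a group carrying a five-membered non-aromatic ring is accepted there and goes with a far lower number. Nothing measured on the group bears on this result, so the step stands without an explanation.

From the compounds shown here alone, whether the step belongs to the sulfonyl or to the pyrrolidine ring remains open; a methylsulfonyl group, an unsubstituted sulfonamide or a carboxamide at the same carbon would separate the two. Going by these compounds, it is also open whether the same step would appear with the other side of the molecule as in compound 1 or compound 2.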